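A few compounds are considered here, and "the series" means these few. Any claim that something is new, unique, unknown or untested is made for them only; others in the source may bear on it.

Measured compounds:
compound 1, `COC(=O)c1c(Nc2ccccc2)sc(C(=O)c2ccc(OC)cc2)c1C`, in a functional assay, with a stated time of 150 min, tested at 25 ug/mL (on this read-out lower numbers stand for a weaker effect and higher numbers for a stronger effect at the one concentration tested), gives 36.9%.
compound 2, `COC(=O)c1c(Nc2ccccc2)sc(C(=O)c2ccc(C)cc2)c1C`, in this assay gives 8.16%.
compound 3, `COc1ccc(C(=O)c2sc(Nc3ccc(C)cc3)c(C(=O)O)c2C)cc1`, in this assay is reported as "not active" (no number reported), without a number.

Compound 2 and compound 1 differ by methoxy in place of methyl on an aromatic carbon, and this step gives a number 28.7 percentage points higher from compound 2 to compound 1 (beyond the scatter). Compound 4, `COc1ccc(Nc2sc(C(=O)c3ccc(OC)cc3)c(C)c2C(=O)O)cc1`, is not yet measured; it differs from compound 3 by methoxy in place of methyl on an aromatic carbon, the same kind of change, here cut one bond further out as (4-methylphenyl)amino to (4-methoxyphenyl)amino rather than 4-methylphenyl to 4-methoxyphenyl. The difference between the core of compound 2 and the core of compound 3 is not broken down here. A step of similar size as from compound 2 to compound 1 is possible, but it starts from compound 3, which gave no number, so the expectation is cautious. For compound 4 in this assay the expected value is 12%, within 0% to 38%.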

Compound 4, a percentage reported as activity, at one concentration (the size of the read-out at that concentration, not a potency): 38.5%
For compound 4 the middle estimate is 26.5 percentage points below the measured one; measured number above the stated range.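

Among the compounds shown here, compound 3 carries no number in this assay, so no step to compound 4 can be read. Nothing measured here offers an explanation for the result of compound 4. The compounds shown leave open what the core difference between compound 1 and compound 4 contributes on its own.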